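Extending the chain on compound 1

The compounds below may be only part of what the source reports. "The series", "measured", "known", "first", "only" and "open" are said of these compounds alone.

In a functional assay on HT-29 cells (Homo sapiens) for antiproliferative activity, read by sulforhodamine B assay, with a stated time of 48 h (a lower number here means a stronger inhibitor, a higher number a weaker inhibitor), compound 1 `CN1CCN(c2ccc(S(=O)(=O)Oc3cc(Cl)c(Cl)cc3Cl)cc2)C1=O` gives 600 nM as the lower of the two numbers shown. In this assay compound 3 `CCN1CCN(c2ccc(S(=O)(=O)Oc3cccc(Br)c3)cc2)C1=O` gives 3800 nM as a number beyond the scatter from that of compound 1. In this assay compound 2 `COc1ccc(OS(=O)(=O)c2ccc(N3CCN(C)C3=O)cc2)cc1` reads > 100000 nM and this is a limit, not a number. Compound 4 `CCCN1CCN(c2ccc(S(=O)(=O)Oc3cc(Cl)c(Cl)cc3Cl)cc2)C1=O` differs from compound 1 by ethyl in place of hydrogen on a saturated chain carbon bound to an amide-type nitrogen in a ring and the same difference reads methyl to propyl. Going by the values given here, no measured pair shows this change alone. In this assay no step beyond the scatter is expected, and this expectation starts from compound 1 at 600 nM as its only anchor. The estimated step is a 1.3-fold higher number from compound 1 to compound 4 (0.12 log units; within the scatter) and is expected to stay small. The estimated value for compound 4 is 800 nM with an expected range from 250 nM to 2500 nM in this series.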

Compound 4, half-maximal inhibitory concentration: 19000 nM
For compound 4 the middle estimate is 24-fold (1.38 log units) below the measured one; the whole stated range lies below it.
By their numbers in this assay, from the lowest: compound 1; then compound 3; then compound 4. At a limit, above all of these: compound 2.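

In this assay this position proves sensitive to chain length: the change of methyl to propyl, with the rest of compound 1 unchanged, gives a 32-fold higher number from compound 1 to compound 4 (1.50 log units; beyond the scatter) as a clear loss of activity. Going by these compounds alone, no earlier pair isolated this position. Nothing measured among the data shown accounts for this step.

As far as these compounds go, whether ethyl on the core of compound 1 reads closer to methyl or to propyl stays open. Also open, from the compounds shown here alone, is how this position responds to a longer chain such as butyl, or to a chain ending in an amine or a carboxylic acid.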